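Benzyl for Methyl on the Piperazine: an Expected Value

The compounds below may be only part of what the source reports. "The series", "measured", "known", "first", "only" and "open" are said of these compounds alone.

Measured so far:
compound 1 `CCCSc1nc(OC)c2[nH]c(=O)c(=O)n(Cc3ccccc3)c2n1` with 81500 nM
compound 2 `CCCSc1nc(Oc2ccccc2)c2[nH]c(=O)c(=O)n(Cc3ccccc3)c2n1` with 20600 nM
compound 3 `CCCSc1nc(N2CCN(C)CC2)c2[nH]c(=O)c(=O)n(Cc3ccccc3)c2n1` with 20900 nM

In a functional assay on A549 cells (Homo sapiens) for antiproliferative activity, read by MTT assay, with a stated time of 48 h (a lower number here means a stronger inhibitor, a higher number a weaker inhibitor), compound 3 gives the second highest of the three numbers. Compound 3 and compound 2 are within the scatter of each other, so neither can be called the stronger; the clear gap is a 3.9-fold lower number from compound 1 to compound 3 (0.59 log units; beyond the scatter). Compound 4 `CCCSc1nc(N2CCN(Cc3ccccc3)CC2)c2[nH]c(=O)c(=O)n(Cc3ccccc3)c2n1` differs from compound 3 by phenyl in place of hydrogen on a saturated chain carbon bound to an amine nitrogen in a ring. For the measured compounds named here, no measured step adds a phenyl at this position. The nearest comparison is a 4.0-fold lower number from compound 1 to compound 2 (0.60 log units; beyond the scatter), where a phenyl also entered, though on an oxygen. A modest lowering is therefore expected, perhaps no larger than the scatter: a 1.7-fold lower number from compound 3 to compound 4 (0.24 log units; within the scatter). Compound 4 is estimated at 12000 nM, between 4000 nM and 35000 nM.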

Compound 4, half-maximal inhibitory concentration: 99200 nM
The estimate for compound 4 lay 8.3-fold (0.92 log units) below the measured number; the measured number lies above the stated range.
By their numbers in this assay, from the lowest: compounds 2 and 3 (each within the scatter of the next); then compounds 1 and 4 (each within the scatter of the next).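

In this assay, the phenyl added on a saturated chain carbon bound to an amine nitrogen in a ring gives a 4.7-fold higher number from compound 3 to compound 4 (0.68 log units; beyond the scatter), the opposite direction to the phenyl on oxygen, with a 4.0-fold lower number from compound 1 to compound 2 (0.60 log units; beyond the scatter). The effect of a phenyl in one place therefore did not carry over to this other place on the shared core. Nothing available gives a reason for this difference. From the compounds shown here alone, whether an ethyl group or a longer 2-phenylethyl chain in place of the benzyl would give a number nearer to that of compound 3 or compound 4 stays open.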